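Working notes: from compound 3 to compound 4

This account rests on a few compounds, and the source may have more. Where it says the series, first, only, none or still open, it means among the compounds named here.

Readings in an ADME assay on HEK-293T cells (Homo sapiens) for inhibition, read by CCK-8 assay, with a stated time of 48 h, tested at 20 uM; a higher number here means more inhibition of growth at the concentration tested, a lower number less inhibition of growth:
- compound 1 `COc1ccc(S(=O)(=O)Oc2ccccc2/C=C(\C#N)C(=O)Nc2nnc(Cc3cccc(F)c3)s2)cc1`: 29%
- compound 2 `N#C/C(=C\c1ccccc1OS(=O)(=O)c1ccc([N+](=O)[O-])cc1)C(=O)Nc1nnc(Cc2cccc(F)c2)s1`: "not toxic" (no number reported)
- compound 3 `N#C/C(=C\c1ccccc1OS(=O)(=O)c1ccc(F)cc1)C(=O)Nc1nnc(Cc2cccc(F)c2)s1`: 17%

Going by the values given here, only two of these readings are numbers, and compound 3 holds the lower one, 17%. Compound 1 is the nearest and only numeric neighbour, and compound 2 offers no number for comparison.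

Compound 4 `N#C/C(=C\c1ccccc1OS(=O)(=O)c1ccc(F)cc1)C(=O)Nc1nnc(Cc2ccc(Cl)cc2)s1` carries one change from compound 3: 4-chlorophenyl in place of 3-fluorophenyl on a saturated chain carbon bound to an aromatic carbon. This places 4-chlorophenyl in place of 3-fluorophenyl on a saturated chain carbon bound to an aromatic carbon.

Among the compounds with values here, the sole measured step, a number 12 percentage points lower from compound 1 to compound 3 (beyond the scatter), is modest and lies in a different part of the molecule. Within the data shown here, it therefore indicates only what size of step this series can show, and no measured step covers the new change. A step within the scatter in this assay is expected, with no firm direction.

The expected step is a number 2 percentage points higher from compound 3 to compound 4 (within the scatter).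

For compound 4 the estimate is 19%, with an expected range of 7% to 34%.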

Compound 4, percent growth inhibition at one concentration: 14%
Compound 4: the middle estimate sits 5 percentage points above what was measured; the measured number falls inside the stated range.
By their numbers in this assay, from the lowest: compounds 4 and 3 (each within the scatter of the next); then compound 1.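

Going by these compounds alone, the first measured step on a saturated chain carbon bound to an aromatic carbon reads a number 3 percentage points lower from compound 3 to compound 4 (within the scatter) in this assay. Within the data shown here, the earlier step concerned only fluoro in place of methoxy on an aromatic carbon, whereas this one shows that 3-fluorophenyl and 4-chlorophenyl at the new position give readings within the scatter of each other, for the one pair tested. The change swaps both the halogen and its place on the phenyl ring, so this single step cannot separate the two, and nothing shown gives a reason for the reading.

From the compounds shown here alone, whether 3-chlorophenyl or 4-fluorophenyl would read alike remains open. So does whether the position tolerates groups of another kind, such as an unsubstituted phenyl, a pyridine ring, an amine or a carboxylic acid.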